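This account rests on a few compounds, and the source may have more. Where it says the series, first, only, none or still open, it means among the compounds named here.

In a functional assay on HepG2 cells (Homo sapiens) for antiproliferative activity, read by MTT assay, with a stated time of 48 h (a higher number here means a weaker inhibitor, a lower number a stronger inhibitor), three compounds sharing one core have been measured. Compound 1 (`O=[N+]([O-])c1ccccc1CSc1nnc(-c2ccc3c(c2)OCCO3)o1`) gives 38100 nM, compound 2 (`c1ccc(CSc2nnc(-c3ccc4c(c3)OCCO4)o2)cc1`) gives 32100 nM, and compound 3 (`Cc1ccc(CSc2nnc(-c3ccc4c(c3)OCCO4)o2)cc1`) gives 41900 nM. Compound 3 therefore stands level with the other two, its number lying within the scatter of both.

The next compound, compound 4 (`Clc1ccccc1CSc1nnc(-c2ccc3c(c2)OCCO3)o1`), departs from compound 3 in one place: 2-chlorophenyl in place of 4-methylphenyl on a saturated chain carbon bound to a sulfur. In words, 2-chlorophenyl comes in place of 4-methylphenyl on a saturated chain carbon bound to a sulfur.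

Within the data shown here, two measured steps bear on this change, although neither involves 2-chlorophenyl itself. Hydrogen in place of nitro on an aromatic carbon gave a 1.2-fold lower number from compound 1 to compound 2 (0.07 log units; within the scatter), and methyl in place of hydrogen on an aromatic carbon gave a 1.3-fold higher number from compound 2 to compound 3 (0.12 log units; within the scatter). Both steps are small and stay within the scatter. Among the measured compounds shown here, compound 4 has no direct measured precedent, so this expectation rests only on those two steps. No step beyond the scatter is expected in this assay, and no firm direction can be assigned. The estimated change is a 1.2-fold lower number from compound 3 to compound 4 (0.08 log units; within the scatter). For compound 4 the expected value is 35000 nM, with an estimated range from 18000 nM to 60000 nM.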

Compound 4, half-maximal inhibitory concentration: 22600 nM
For compound 4 the middle estimate is 1.5-fold (0.19 log units) above the measured one; the measured number falls inside the stated range.
By their numbers in this assay, from the lowest: compounds 4, 2, 1 and 3 (each within the scatter of the next).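

In this assay, 4-methylbenzyl gives way to 2-chlorobenzyl with a 1.9-fold lower number from compound 3 to compound 4 (0.27 log units; within the scatter), the widest step seen so far on the group carried by the saturated chain carbon bound to a sulfur, yet still within the scatter. Chloro can now be set against hydrogen, which gives a 1.4-fold lower number from compound 2 to compound 4 (0.15 log units; within the scatter), and against nitro, which gives a 1.7-fold lower number from compound 1 to compound 4 (0.23 log units; within the scatter), so that neither step separates the chloro compound from its neighbours, and the hydrogen, nitro, methyl and chloro compounds all remain level in this assay. The compounds come with no measurement that could account for these small differences.

As far as these compounds go, whether an amine or a carboxylic acid on the aromatic ring of the benzyl group, or a longer chain in place of that group on the sulfur, would produce a step beyond the scatter remains open. So does the effect of any change to the shared core, which stays the same in all four compounds.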